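From pyridin-4-yl to pyridin-3-yl in a cell toxicity test

The source may hold more compounds than are shown below. What is called first, only, known or untested is meant among the compounds shown, and "the series" means these compounds.

compound 1 `COc1cc(OCC=C(C)C)ccc1C(=O)/C=C/c1cccnc1` gives 22000 nM
compound 2 `C#CCOc1ccc(C(=O)/C=C/c2cccnc2)c(O)c1` gives 40000 nM
compound 3 `C#CCOc1ccc(C(=O)/C=C/c2ccncc2)c(OC)c1` gives 20000 nM

All three numbers come from an ADME assay on Vero cells (Chlorocebus sabaeus) for cytotoxicity, read by resazurin assay, with a stated time of 72 h (on this read-out lower numbers stand for higher toxicity in this test and higher numbers for lower toxicity in this test), and they sit close together. Compound 3 stands at 20000 nM in this test, within the usual scatter of both other compounds, so these numbers do not set it apart.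

Compound 4 `C#CCOc1ccc(C(=O)/C=C/c2cccnc2)c(OC)c1` has not been measured yet. It has the same atoms as compound 3, joined differently: the change is pyridin-3-yl in place of pyridin-4-yl on a double-bonded chain carbon bound to a double-bonded chain carbon and it places pyridin-3-yl in place of pyridin-4-yl on a double-bonded chain carbon bound to a double-bonded chain carbon.

Going by the values given here, no pair of measured compounds shows this swap on its own. Still, pyridin-3-yl is carried by compound 1 at 22000 nM and by compound 2 at 40000 nM in this assay and neither lies beyond the scatter from compound 3. No step beyond the scatter is therefore expected: the estimated step is a 1.2-fold higher number from compound 3 to compound 4 (0.08 log units; within the scatter) and nothing more. The estimated value for compound 4 is 24000 nM with an expected range from 12000 nM to 50000 nM in this test.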

Compound 4, half-maximal cytotoxic concentration: 15000 nM
Compound 4: middle estimate off by 1.6-fold (0.20 log units), on the high side; low and high end bracket the measured number.
By their numbers in this assay, from the lowest: compounds 4, 3, 1 and 2 (each within the scatter of the next, the first and the last beyond it).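

Pyridin-3-yl in place of pyridin-4-yl on a double-bonded chain carbon bound to a double-bonded chain carbon can now be read on its own in this assay and gives a 1.3-fold lower number from compound 3 to compound 4 (0.12 log units; within the scatter) with no clear effect on the result. Methyl in place of hydrogen on an oxygen on an aromatic ring gives a 2.7-fold lower number from compound 2 to compound 4 (0.43 log units; beyond the scatter) as the only new step beyond the scatter, whereas ethynyl in place of 2-methylprop-1-en-1-yl on a saturated chain carbon bound to an oxygen on an aromatic ring gives a 1.5-fold lower number from compound 1 to compound 4 (0.17 log units; within the scatter) and stays inside it. No measurement here accounts for any of these steps.

Still open, from the compounds shown here alone, is whether an amine or a carboxylic acid in place of the pyridin-3-yl would move the number beyond the scatter. Going by these compounds, a longer chain in place of the methyl on that oxygen is equally open.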